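Cytotoxicity notes on three measured analogues and one expected

This account rests on a few compounds, and the source may have more. Where it says the series, first, only, none or still open, it means among the compounds named here.

Measured so far in an ADME assay on HEK-293T cells (Homo sapiens) for cytotoxicity, read by luminescence, with a stated time of 24 h; on this read-out higher numbers stand for lower toxicity in this test and lower numbers for higher toxicity in this test:
compound 1, `COc1ccc(Cn2c(C(=O)N3CCC(C(=O)NCc4ccccc4)CC3)cc3sccc32)cc1`, gives > 100000 nM, which is a limit of the assay.
compound 2, `COc1ccc(Cn2c(C(=O)N3CCC(C(=O)NC(C)c4ccccc4)CC3)cc3sccc32)cc1`, gives > 100000 nM, which is also a limit of the assay.
compound 3, `CCCNC(=O)C1CCN(C(=O)c2cc3sc(CNC(C)c4ccccc4)cc3n2Cc2ccc(OC)cc2)CC1`, gives 33900 nM.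

Compound 3 is thus the only one of the three with a number; the other two values are limits. Both limits sit at the same point, (the limit of > 100000 nM in this assay, at which 2 of the 3 values shown sit). Compound 2 and compound 1 differ by hydrogen in place of methyl on a saturated chain carbon bound to an amide-type nitrogen and an aromatic carbon, and the step that the two limits leave unreadable from compound 2 to compound 1 cannot be read, since each end is a limit. How the core of compound 3 differs from the core of compound 2 is not broken down here.

The unmeasured compound 4, `CCCNC(=O)C1CCN(C(=O)c2cc3sc(CNCc4ccccc4)cc3n2Cc2ccc(OC)cc2)CC1`, differs from compound 3 by hydrogen in place of methyl on a saturated chain carbon bound to an amine nitrogen and an aromatic carbon. This is the same kind of change as that from compound 2 to compound 1, though not the same: in the earlier pair the carbon is bound to an amide-type nitrogen, here it is bound to an amine nitrogen. The earlier step gives no readable size, so the expectation for compound 4 rests on compound 3 alone, because compound 3 gives 33900 nM and the change removes only a methyl. The step of a 1.2-fold higher number from compound 3 to compound 4 (0.07 log units; within the scatter) is expected to stay small. Compound 4 is therefore expected to give about 40000 nM, within the range 15000 nM to 100000 nM.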

Compound 4, half-maximal cytotoxic concentration: 46800 nM
Estimate against measurement, compound 4: 1.2-fold (0.07 log units) below; measured number inside the range.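

Where the carbon is bound to an amine nitrogen, hydrogen in place of methyl gives a 1.4-fold higher number from compound 3 to compound 4 (0.14 log units; within the scatter) in this assay, so this single pair shows no difference that stands out from the scatter. The same kind of change, with the carbon bound to an amide-type nitrogen, links compound 2 and compound 1, but each of these two compounds gives only a limit of the assay, so that step cannot be read: the limit of > 100000 nM in this assay, at which 2 of the 4 values shown sit.

Carrying the change from one core to another is therefore neither supported nor contradicted, since the series offers one readable pair and no second step to set against it.

The compounds shown leave open whether the change from 1-phenylethyl to benzyl would stay within the scatter on a core where both members of the pair give a number rather than a limit. Also open is how this assay responds to a larger change at the same carbon, such as an ethyl group, a longer chain or a carboxylic acid in place of the methyl, as the only replacement shown here is hydrogen.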